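A Second Trifluoromethyl on the Shared Core

The source may report more compounds than this note shows. Statements on the series, on what has been measured and on what is new or still open speak of the compounds shown alone.

Compound 1, `C[C@@H](NC(=O)Nc1cccc(C(F)(F)F)c1)c1ccccc1`: 70%
Compound 2, `C[C@@H](NC(=O)Nc1cccc(Cl)c1)c1ccccc1`: 83%
Compound 3, `C[C@@H](NC(=O)Nc1cccc(I)c1)c1ccccc1`: 73%

In an ADME assay on the whole organism with Oryza sativa as the target, tested at 10 uM (on this read-out higher numbers stand for a weaker effect at the one concentration tested and lower numbers for a stronger effect), compound 1 gives 70%, the lowest of the three numbers; compound 3 is nearest, a number 3 percentage points higher from compound 1 to compound 3 (within the scatter), and compound 2 furthest, a number 13 percentage points higher from compound 1 to compound 2 (beyond the scatter). Compound 4, `C[C@@H](NC(=O)Nc1cc(C(F)(F)F)cc(C(F)(F)F)c1)c1ccccc1`, differs from compound 1 by trifluoromethyl in place of hydrogen on an aromatic carbon; the group enters on an aromatic carbon, meta to a trifluoromethyl group. Within the data shown here, no measured step swaps hydrogen for trifluoromethyl. Among the measured compounds shown here, those closest to it exchange the one group on that ring: the step to compound 2 is modest, while a number 10 percentage points lower from compound 2 to compound 3 (within the scatter) stays within the scatter. A second trifluoromethyl is therefore expected to move the number little, and compound 4 is estimated at 66% (range 50% to 82%), an expected step of a number 4 percentage points lower from compound 1 to compound 4 (within the scatter) within the scatter.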

Compound 4, a percentage reported as activity, at one concentration (the size of the read-out at that concentration, not a potency): 53%
Estimate against measurement, compound 4: 13 percentage points above; measured number inside the range.
By their numbers in this assay, from the lowest: compound 4; then compounds 1, 3 and 2 (each within the scatter of the next, the first and the last beyond it).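

Trifluoromethyl in place of hydrogen on an aromatic carbon, meta to a trifluoromethyl group, gives a number 17 percentage points lower from compound 1 to compound 4 (beyond the scatter) in this assay and so a stronger effect at the one concentration tested. Among these compounds, the earlier compounds varied only the one group on that ring, whereas this step shows that a second carbon of the ring also bears on the read-out. Nothing measured here accounts for the step. As far as these compounds go, whether an amine or a methyl group on this carbon would move the number as far remains open, as does whether the step depends on the trifluoromethyl group already present.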